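The compounds below may be only part of what the source reports. "The series", "measured", "known", "first", "only" and "open" are said of these compounds alone.

Measured compounds:
compound 1 `C#CCN(C)CCCCCOc1ccc2c(c1)CCCC2=O`; compound 2 `C#CCN(C)CCCOc1ccc2c(c1)OCCC2=O`; compound 3 `C#CCN(C)CCCCOc1ccc2c(c1)OCCC2=O`

In an assay on BTI cells for inhibition of Amine oxidase [flavin-containing] B (Homo sapiens), read by fluorescence and Amplex Red, with a stated time of 15 min (a higher number here means a weaker inhibitor, a lower number a stronger inhibitor), compound 1 gives 46.3 nM. In the same assay compound 2 gives 11400 nM, and compound 3 gives 58.9 nM. Compound 3 therefore stands second highest of the three numbers; its nearest neighbour is compound 1, within the scatter, and its furthest is compound 2, the gap being a 190-fold lower number from compound 2 to compound 3 (2.29 log units; beyond the scatter).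

The step considered is compound 4 `C#CCN(C)CCCCCOc1ccc2c(c1)OCCC2=O`, which differs from compound 3 by (methyl(propargyl)amino)methyl in place of methyl(propargyl)amino on a saturated chain carbon, four bonds along the chain from an oxygen on an aromatic ring. Going by the values given here, the one measured step that bears on it is the same kind of chain extension one bond closer to the aromatic oxygen, a 190-fold lower number from compound 2 to compound 3 (2.29 log units; beyond the scatter), a large drop. The longer chain of compound 4 sits on a different core in compound 1, and compound 1 gives 46.3 nM, within the scatter of compound 3. The expectation is that a second extension brings at most a small further gain: a 1.7-fold lower number from compound 3 to compound 4 (0.23 log units; within the scatter) is expected, not clearly beyond the scatter. Compound 4 is therefore estimated at 35 nM, within 10 nM to 120 nM.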

Compound 4, half-maximal inhibitory concentration: 4 nM
Compound 4: middle estimate off by 8.8-fold (0.94 log units), on the high side; measured number outside the range, below it.
By their numbers in this assay, from the lowest: compound 4; then compounds 1 and 3 (each within the scatter of the next); then compound 2.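

In this assay the second extension, (methyl(propargyl)amino)methyl in place of methyl(propargyl)amino on a saturated chain carbon, four bonds along the chain from an oxygen on an aromatic ring, still brings a large gain (a 15-fold lower number from compound 3 to compound 4 (1.17 log units; beyond the scatter)), so the benefit of lengthening had not run out at compound 3. Over both extensions on the shared core, the change to 2-(methyl(propargyl)amino)ethyl amounts to a far larger step (a 2900-fold lower number from compound 2 to compound 4 (3.45 log units; beyond the scatter)), and among compounds 2, 3 and 4 each added chain carbon lowers the number, with none going against this. No evidence is available that accounts for the size of either step.

On these data alone, whether a longer chain would lower the number further or reverse the trend stays open, as does whether the same extension holds on the core of compound 1. As far as these compounds go, the effect of dimethylamino in place of methyl(propargyl)amino at the chain end also stays open.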